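A few compounds are considered here, and "the series" means these few. Any claim that something is new, unique, unknown or untested is made for them only; others in the source may bear on it.

Among the measured compounds shown here, compound 1 `CC(C)CC1n2cncc2CN(Cc2ccc(OC(F)(F)F)cc2)S1(=O)=O` has the higher of the two numbers measured so far: in an assay on cells for inhibition of cytochrome P450 11B2, mitochondrial (Homo sapiens) (a higher number here means a weaker inhibitor, a lower number a stronger inhibitor), compound 1 gives 104 nM, while compound 2 `C[C@@H](c1ccc(Cl)cc1)N1Cc2cncn2C(C[C@@H](O)c2ccccc2)S1(=O)=O` gives 2.4 nM, a gap beyond the scatter. Compound 3 `CC(C)CC1n2cncc2CN(Cc2ccc(F)cc2)S1(=O)=O` differs from compound 1 by fluoro in place of trifluoromethoxy on an aromatic carbon. For the measured compounds named here, no measured pair tests this change, so its size in this assay is unknown. A modest weakening is expected, a 1.7-fold higher number from compound 1 to compound 3 (0.24 log units; within the scatter). Compound 3 is estimated at 180 nM in this assay, within a range of 50 nM to 600 nM.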

Compound 3, half-maximal inhibitory concentration: 2.5 nM
Beside the measured number, compound 3's estimate is 72-fold (1.86 log units) above it; the measured number lies below the stated range.
By their numbers in this assay, from the lowest: compounds 2 and 3 (each within the scatter of the next); then compound 1.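

Fluoro in place of trifluoromethoxy gives a 42-fold lower number from compound 1 to compound 3 (1.62 log units; beyond the scatter) in this assay and so shows that the group on this aromatic carbon can strongly shift the number on an otherwise unchanged structure. Of these two groups, fluoro gives the far lower number, although this rests on a single pair. Nothing on hand accounts for the size of this step.

Where chloro, methoxy or a nitrile on this aromatic carbon would fall remains open. Among the compounds shown here, also open is whether the step would hold with a chain other than the one shared by compound 1 and compound 3.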